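The source may hold more compounds than are shown below. What is called first, only, known or untested is meant among the compounds shown, and "the series" means these compounds.

Compound 1 `Fc1ccc(-c2n[nH]cc2/C=N/n2c(OCc3ccccc3Cl)n[nH]c2=S)cc1`: 71 ug/mL
Compound 2 `CCc1n[nH]cc1/C=N/n1c(OCc2ccc(C)cc2)n[nH]c1=S`: > 100 ug/mL

In a functional assay on HepG2 cells (Homo sapiens) for cytotoxicity, read by MTT assay, with a stated time of 24 h (on this read-out higher numbers stand for weaker inhibition and lower numbers for stronger inhibition), compound 1 gives 71 ug/mL. Compound 2 in this assay reaches only the limit of the assay, > 100 ug/mL, so no number is known for it; this is the limit of > 100 ug/mL in this assay, at which 1 of the 2 values shown sits. Compound 3 `Cc1ccc(COc2n[nH]c(=S)n2/N=C/c2c[nH]nc2-c2ccc(F)cc2)cc1` has not yet been measured in this assay. It differs from compound 2 in one place: 4-fluorophenyl in place of ethyl on an aromatic carbon. No measured pair differs in that place alone, so the size of such a step cannot be read from the numbers shown. Compound 1 carries the same 4-fluorophenyl group on the same five-membered ring, though with a different group on the other side of the shared core, and it gives a number in this assay. Compound 2 does not. The comparison allows a move toward stronger inhibition for compound 3 but does not require one. Compound 3 is therefore expected to sit near the limit, at 85 ug/mL, with a range from 45 ug/mL to 150 ug/mL. The step from compound 2 to compound 3 is estimated as an at least 1.1-fold lower number from compound 2 to compound 3 (0.07 log units; that floor lies within the scatter), which may amount to no more than the usual scatter.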

Compound 3, half-maximal inhibitory concentration: 45 ug/mL
For compound 3 the middle estimate is 1.9-fold (0.28 log units) above the measured one; measured number inside the range.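

In this assay, among these compounds, putting 4-fluorophenyl in place of ethyl on an aromatic carbon of the five-membered aromatic ring with 2 nitrogen gives an at least 2.2-fold lower number from compound 2 to compound 3 (0.34 log units; beyond the scatter), the first step at this position that can be read from measured compounds, and it lies beyond the scatter. That step is only a floor, as one end of it is not a number, and compound 2 remains a limit of the assay: the limit of > 100 ug/mL in this assay, at which 1 of the 3 values shown sits. With 4-fluorophenyl held at this position, 4-methylphenyl in place of 2-chlorophenyl on a saturated chain carbon bound to an oxygen on an aromatic ring gives a 1.6-fold lower number from compound 1 to compound 3 (0.20 log units; within the scatter), so this second change does not separate the two compounds beyond the scatter.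

The compounds shown leave open whether the step belongs to 4-fluorophenyl itself, or whether an unsubstituted phenyl, a 4-methoxyphenyl or a longer chain such as butyl on the same carbon would give a similar one. From the compounds shown here alone, they also leave open how large the step truly is, since how far the number for compound 2 lies past its limit is unknown.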